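The compounds below may be only part of what the source reports. "The series", "measured", "known", "first", "only" and "open" are said of these compounds alone.

Compound 1 `Cc1ccc(C(=O)Nc2cc3nncn3c(CN3CCN(C(=O)C4CCCC4)[C@@H](C)C3)c2C)cn1` gives 59 mL.min-1.g-1 in an ADME assay on microsomes from liver (Homo sapiens) for metabolic stability; a lower number here means slower removal, a higher number faster removal of the compound. Compound 2 `Cc1ccc(C(=O)Nc2cn3ncnc3c(CN3CCN(C(=O)CCC(F)(F)F)[C@@H](C)C3)c2C)cn1` reads < 10 mL.min-1.g-1 in this assay, which is a limit of the assay and not a number. Compound 2 thus stands at the limit of < 10 mL.min-1.g-1 in this assay, at which 1 of the 2 values shown sits.

Compound 3 `Cc1ccc(C(=O)Nc2cn3ncnc3c(CN3CCN(C(=O)CC(C)C)[C@@H](C)C3)c2C)cn1` keeps the structure of compound 2 except for one change in the side chain on the amide carbonyl: isopropyl in place of 2,2,2-trifluoroethyl on a saturated chain carbon bound to a carbonyl carbon. In words, this is isopropyl in place of 2,2,2-trifluoroethyl on a saturated chain carbon bound to a carbonyl carbon, which can also be read as 3,3,3-trifluoropropyl changing to isobutyl.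

Among the compounds with values here, no measured pair here isolates this change, so the size of the step has to be judged rather than read off. With compound 2 at < 10 mL.min-1.g-1, a limit, any visible change can only run toward faster removal. A moderate rise, beyond the usual scatter, is the expectation, and the estimated step is an at least 2.0-fold higher number from compound 2 to compound 3 (0.30 log units; that floor lies within the scatter). For compound 3 the expected intrinsic clearance in microsomes is 20 mL.min-1.g-1, with an estimated range of 10 mL.min-1.g-1 to 45 mL.min-1.g-1.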

Compound 3, intrinsic clearance in microsomes: 20 mL.min-1.g-1
The estimate for compound 3 equals the measured number at the digits printed; measured number inside the range.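

Within the data shown here, the first pair here that differs in one place, with isopropyl in place of 2,2,2-trifluoroethyl on a saturated chain carbon bound to a carbonyl carbon, gives an at least 2.0-fold higher number from compound 2 to compound 3 (0.30 log units; that floor lies within the scatter) in this assay. Compound 2 remains a limit of the assay and not a number: the limit of < 10 mL.min-1.g-1 in this assay, at which 1 of the 3 values shown sits.

With isobutyl as the side chain on the amide carbonyl, compound 3 gives a true number on the same core, 20 mL.min-1.g-1. From the compounds shown here alone, the full size of the step stays unknown, and its printed floor alone does not establish a change beyond the usual scatter.

Compound 1, at 59 mL.min-1.g-1, differs from compound 2 and compound 3 in more than one place, so its steps to them cannot be read. The compounds shown also leave open whether the fluorine atoms or the shape of the chain accounts for the difference, and how the read-out would respond to a longer straight chain, or to an amine or a carboxylic acid at the end of this side chain.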